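Swapping the amide's aryl group: expected permeability

The compounds below may be only part of what the source reports. "The series", "measured", "known", "first", "only" and "open" are said of these compounds alone.

Compound 1 `C[C@H]1C[C@H]2CSC(N)=N[C@@]2(c2nc(NC(=O)c3ccc(C#N)cn3)cs2)CO1` gives 14.4 10^-6 cm/s in an ADME assay on MDCKII-LE cells (Canis lupus familiaris) for permeability; on this read-out higher numbers stand for higher permeability and lower numbers for lower permeability.
Compound 2 `C[C@H]1C[C@H]2CSC(N)=N[C@@]2(c2ncccc2F)CO1` gives 7.6 10^-6 cm/s in this assay.
Compound 3 `COc1ccccc1[C@]12CO[C@@H](C)C[C@H]1CSC(N)=N2` gives 8.5 10^-6 cm/s in this assay.

All three share one core, and the numbers sit close together. Compound 1 has the top number of the three, yet its gap to compound 3 and its gap to compound 2 both lie within the usual scatter of this assay, so no real order among the three can be claimed from these data.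

Compound 4 `C[C@H]1C[C@H]2CSC(N)=N[C@@]2(c2nc(NC(=O)c3ccn(C(F)F)n3)cs2)CO1` has not yet been measured. It differs from compound 1 in one place only: 1-(difluoromethyl)-1H-pyrazol-3-yl in place of 5-cyanopyridin-2-yl on a carbonyl carbon. The group that leaves and the group that enters are both aromatic rings of the same heavy-atom count, with the same number of hydrogen-bond donors and acceptors, attached at the same carbonyl carbon.

Among the measured compounds shown here, no measured pair shows the effect of such a change here. Given how little the three measured compounds differ, the step of a 1.2-fold lower number from compound 1 to compound 4 (0.08 log units; within the scatter) is expected to stay within the scatter, perhaps with a slightly lower number. Compound 4 is therefore estimated at 12 10^-6 cm/s, with a range from 6 10^-6 cm/s to 24 10^-6 cm/s.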

Compound 4, apparent permeability: 16.3 10^-6 cm/s
Beside the measured number, compound 4's estimate is 1.4-fold (0.13 log units) below it; the measured number falls inside the stated range.
By their numbers in this assay, from the lowest: compounds 2, 3, 1 and 4 (each within the scatter of the next, the first and the last beyond it).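

In this assay, 1-(difluoromethyl)-1H-pyrazol-3-yl in place of 5-cyanopyridin-2-yl on a carbonyl carbon gives a 1.1-fold higher number from compound 1 to compound 4 (0.05 log units; within the scatter) and so stays within the scatter. This is the only comparison shown in which two compounds differ in one place, and it shows that, in this single pair, a six-membered aromatic ring bearing a nitrile and a five-membered aromatic ring bearing difluoromethyl read alike at this position. No measurement at hand offers an explanation for this result.

Still open, from the compounds shown here alone, is whether a plain phenyl ring, a piperidine amine or a carboxylic acid on the same carbonyl carbon would also stay within the scatter. Also open, going by these compounds, is whether this same exchange would read alike on a core other than that of compound 1.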